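The source may hold more compounds than are shown below. What is called first, only, known or untested is meant among the compounds shown, and "the series" means these compounds.

Compound 1 `O=C(/C=C/c1ccccc1Cl)c1ccc(OCc2ccccc2)cc1` gives 54.5% in a functional assay on HCT-116 cells (Homo sapiens) for antiproliferative activity, read by sulforhodamine B assay, with a stated time of 3 days, tested at 25 uM; a lower number here means a weaker effect, a higher number a stronger effect of the compound at the concentration tested.
Compound 2 `Cc1ccc(COc2ccc(C(=O)/C=C/c3ccccc3)cc2)cc1` gives 4%.
Compound 3 `O=C(/C=C/c1ccc(OCc2ccccc2)cc1)c1ccccc1` gives 52.3%.

Compound 2 stands lowest of the three numbers, well beyond the scatter below compound 3 and compound 1, which lie within the scatter of each other. The step to compound 4 `O=C(/C=C/c1ccccc1)c1ccc(OCc2ccccc2)cc1` is small in atoms: hydrogen in place of methyl on an aromatic carbon In short, a 4-methylbenzyl becomes a benzyl. Within the data shown here, no two measured compounds differ in just one place, so the size of this kind of step has not been seen here. Because compound 1 with its plain benzyl gives 54.5% and compound 3 with its plain benzyl gives 52.3%, an increase is expected a number 36 percentage points higher from compound 2 to compound 4 (beyond the scatter), with wide uncertainty. Compound 4 is estimated at 40%, between 10% and 60%.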

Compound 4, a percentage reported as inhibition, at one concentration (the size of the read-out at that concentration, not a potency): 24.3%
Compound 4: the middle estimate sits 15.7 percentage points above what was measured, and the stated range covers the measured number.
By their numbers in this assay, from the lowest: compound 2; then compound 4; then compounds 3 and 1 (each within the scatter of the next).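

Hydrogen in place of methyl, para to a large group, gives a number 20.3 percentage points higher from compound 2 to compound 4 (beyond the scatter) in this assay, so even this small change at that position can shift the read-out. Hydrogen in place of chloro on an aromatic carbon gives a number 30.2 percentage points lower from compound 1 to compound 4 (beyond the scatter), showing that removing a substituent does not always act in the same direction. Across these two steps, the outcome depends on which group leaves and where it sat.

As far as these compounds go, whether a methoxy group or an amine at either place would give a higher or lower number remains open. Nothing measured here explains why either step occurs.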